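The compounds below may be only part of what the source reports. "The series", "measured", "known", "first", "only" and "open" are said of these compounds alone.

Compound 1 `COc1ccc2nc(NC(=O)CCCCC(=O)NO)sc2c1`: 23.9 ug/mL
Compound 2 `CCOc1ccc2nc(NC(=O)CCCCCCC(=O)NO)sc2c1`: 9.88 ug/mL

Only these two compounds have so far been measured in a functional assay on ASPC1 cells (Homo sapiens) for cytotoxicity; on this read-out lower numbers stand for stronger inhibition and higher numbers for weaker inhibition. Compound 2 gives the lower number of the pair, 9.88 ug/mL, and compound 1 stands higher at 23.9 ug/mL, a gap beyond the usual scatter.

The next compound to be measured is compound 3 `COc1ccc2nc(NC(=O)CCCCCCC(=O)NO)sc2c1`, which departs from compound 2 in one place: hydrogen in place of methyl on a saturated chain carbon bound to an oxygen on an aromatic ring. This puts hydrogen in place of methyl on a saturated chain carbon bound to an oxygen on an aromatic ring, so that ethoxy becomes methoxy.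

Among the measured compounds shown here, the two measured compounds do not differ in one place only, so no measured step shows what this change does. With so little to go on, no step beyond the scatter is expected in this assay, and no direction can be argued with any confidence. The estimated change is a 1.1-fold higher number from compound 2 to compound 3 (0.05 log units; within the scatter). For compound 3 the expected value is 11 ug/mL, with an estimated range from 4.5 ug/mL to 26 ug/mL.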

Compound 3, half-maximal inhibitory concentration: 0.79 ug/mL
Compound 3: middle estimate off by 14-fold (1.14 log units), on the high side, and the stated range ends above it.
By their numbers in this assay, from the lowest: compound 3; then compound 2; then compound 1.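

In this assay, the alkoxy group proves to be no silent feature: hydrogen in place of methyl on a saturated chain carbon bound to an oxygen on an aromatic ring, turning ethoxy into methoxy, gives a 13-fold lower number from compound 2 to compound 3 (1.10 log units; beyond the scatter), so that a single carbon at this position carries a large step that compounds 1 and 2, which differ in more than one place, could not isolate. The chain also has a large effect of its own with methoxy held constant, since 2-(hydroxycarbamoyl)ethyl in place of hydroxycarbamoyl on a saturated chain carbon, four bonds along the chain from a carbonyl carbon, gives a 30-fold lower number from compound 1 to compound 3 (1.48 log units; beyond the scatter), and the data therefore tie the low value of compound 3 to both the methoxy group and the longer chain. No experimental information bears on how either change produces its step.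

From the compounds shown here alone, it remains open whether a hydroxyl group, a fluorine atom or an amine at the alkoxy position would extend or reverse the step seen with methoxy. Going by these compounds, it is also open whether a still longer chain would carry the trend further, and whether the chain step would have the same size with ethoxy on the core.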